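Extending the Selenium-Bound Chain of Compound 1

The compounds below may be only part of what the source reports. "The series", "measured", "known", "first", "only" and "open" are said of these compounds alone.

Compound 1 `C[Se]c1nc(N)c2ccccc2n1`: 23600 nM
Compound 2 `C[Se]c1nc(N)c2cccnc2n1`: 39700 nM
Compound 3 `CCCCCSc1nc(O)c2ccccc2n1`: 51400 nM

Of the compounds shown here, three have been tested in an ADME assay on BEAS-2B cells (Homo sapiens) for cytotoxicity, read by MTT assay, with a stated time of 72 h; a lower number here means a stronger inhibitor of growth, a higher number a weaker inhibitor of growth. Compound 1 gives 23600 nM, the lowest of the three numbers. Compound 2 gives 39700 nM, which lies within the scatter of compound 1, so no order can be drawn between them. Compound 3 gives 51400 nM, and this gap from compound 1 is beyond the scatter, so compound 1 is the stronger inhibitor of growth of that pair. Compound 3 differs from compound 1 in more than one place, so no single step can be read from it.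

Compound 4 `CCCCC[Se]c1nc(N)c2ccccc2n1` has not been measured. It differs from compound 1 by butyl in place of hydrogen on a saturated chain carbon bound to a selenium atom. Among the compounds with values here, no measured pair shows this change alone. The analyst expects the step from compound 1 to compound 4 to be a 1.1-fold lower number from compound 1 to compound 4 (0.03 log units; within the scatter), not clearly beyond the scatter in either direction. Compound 4 is therefore estimated at 22000 nM, with a range from 8000 nM to 60000 nM.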

Compound 4, concentration for 50% growth inhibition: 52300 nM
Compound 4: the middle estimate sits 2.4-fold (0.38 log units) below what was measured; the measured number falls inside the stated range.
By their numbers in this assay, from the lowest: compounds 1, 2, 3 and 4 (each within the scatter of the next, the first and the last beyond it).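

In this assay, the selenium-bound chain proves to be a place where length registers: methyl to pentyl gives a 2.2-fold higher number from compound 1 to compound 4 (0.35 log units; beyond the scatter), a modest step but one beyond the scatter. Within the data shown here, the earlier compounds offered no pair differing in one place, so this is the first single change that can be read, and it makes the longer-chain compound the weaker inhibitor of growth of that pair. Nothing shown gives a reason for the step.

Going by these compounds, with only two end points, it remains open whether the number rises steadily with length, or how an ethyl, a propyl or a longer chain such as octyl would read. Also open, on these data alone, are how a chain ending in an amine or a carboxylic acid would read here, and whether the same step holds on the core of compound 2.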